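Extending the Ester Alkyl Chain: Expected Cytotoxicity of Compound 4

This account rests on a few compounds, and the source may have more. Where it says the series, first, only, none or still open, it means among the compounds named here.

Compound 1 `CCOC(=O)[C@@H](N)CCC(=O)NCCSC(C)=O` gives 1730000 nM in an ADME assay on HaCaT cells (Homo sapiens) for cytotoxicity, read by MTT assay, with a stated time of 48 h; on this read-out lower numbers stand for an effect already at smaller amounts and higher numbers for an effect only at larger amounts of compound.
Compound 2 `CCOC(=O)[C@@H](N)CCC(=O)NCCSC(=O)C(C)(C)C` gives 228000 nM.
Compound 3 `CCCCOC(=O)[C@@H](N)CCC(=O)NCCSC(=O)C(C)(C)C` gives 102000 nM.

Compound 1 stands highest of the three numbers; the steps away from it are a 7.6-fold lower number from compound 1 to compound 2 (0.88 log units; beyond the scatter) and then a 2.2-fold lower number from compound 2 to compound 3 (0.35 log units; beyond the scatter). Compound 4 `CCCOC(=O)[C@@H](N)CCC(=O)NCCSC(C)=O` differs from compound 1 by methyl in place of hydrogen on a saturated chain carbon, two bonds along the chain from an oxygen next to a carbonyl group. The measured step that bears on this is a 2.2-fold lower number from compound 2 to compound 3 (0.35 log units; beyond the scatter), the same kind of change at the same place, with ethyl rather than methyl entering. A lowering of similar or somewhat smaller size is therefore expected for compound 4 in this assay. Compound 4 is estimated at 1000000 nM, within a range from 500000 nM to 2000000 nM. The expected step is a 1.7-fold lower number from compound 1 to compound 4 (0.24 log units; within the scatter), likely close to the edge of the scatter.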

Compound 4, half-maximal effective concentration in the HaCaT assay: 548000 nM
The estimate for compound 4 lay 1.8-fold (0.26 log units) above the measured number; the measured number falls inside the stated range.
By their numbers in the HaCaT assay, from the lowest: compound 3; then compound 2; then compound 4; then compound 1.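

In the HaCaT assay methyl in place of hydrogen at this place gives a 3.2-fold lower number from compound 1 to compound 4 (0.50 log units; beyond the scatter), so the lowering seen with ethyl in the tert-butyl compounds also appears with a smaller group where methyl sits on the other carbonyl carbon. In a physicochemical assay for lipophilicity, at pH 7.4 (on this read-out lower numbers stand for lower lipophilicity and higher numbers for higher lipophilicity), compound 1 gives -1.44 and compound 4 gives -1.21, values within the usual scatter of each other. No measurement given here explains the step in cytotoxicity.

As far as these compounds go, whether a longer chain at this place lowers the number further remains open. So does what a carboxylic acid in place of the ester would give.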